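A few compounds are considered here, and "the series" means these few. Any claim that something is new, unique, unknown or untested is made for them only; others in the source may bear on it.

Working notes on the series, read in a physicochemical assay for solubility, read by spectrophotometry, measured as kinetic solubility, at pH 8, tested at 500 uM; a higher number here means a more soluble compound, a lower number a less soluble compound. For the measured compounds named here, compound 1 `CNS(=O)(=O)c1ccccc1Nc1cc(-c2ccc3ccn(C)c3c2)c2nccnc2c1` gives 2 ug/mL and compound 2 `CN(C)S(=O)(=O)c1ccccc1Nc1cc(-c2ccc3ccn(C)c3c2)c2nccnc2c1` gives 2 ug/mL, so compound 2 stands level with compound 1, its only measured neighbour. Compound 3 `Cn1ccc2ccc(-c3cc(Nc4ccccc4S(=O)(=O)N4CCOCC4)cc4nccnc34)cc21` is still unmeasured and carries morpholin-4-yl in place of dimethylamino on a sulfonyl sulfur. Going by the values given here, one measured step bears on this part of the structure, no change at the digits printed from compound 1 to compound 2 (within the scatter), with methyl in place of hydrogen on a sulfonamide nitrogen. Among the compounds with values here, that is thin evidence, since no measured step brings in a ring at this place. With nothing measured beyond the scatter, no shift beyond the scatter is expected in this assay. The expected change is no change at the digits printed from compound 2 to compound 3 (within the scatter). Compound 3 is estimated at 2 ug/mL, with an expected range of 1 ug/mL to 5 ug/mL.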

Compound 3, solubility: 5 ug/mL
For compound 3 the middle estimate is 2.5-fold (0.40 log units) below the measured one; low and high end bracket the measured number.
By their numbers in this assay, from the lowest: compounds 1 and 2 (each within the scatter of the next); then compound 3.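

In this assay the change on the sulfonyl sulfur is the only one in the series that moves the number beyond the scatter: morpholin-4-yl in place of dimethylamino gives a 2.5-fold higher number from compound 2 to compound 3 (0.40 log units; beyond the scatter) and morpholin-4-yl in place of methylamino gives a 2.5-fold higher number from compound 1 to compound 3 (0.40 log units; beyond the scatter). Both steps are modest, but they show that this position can respond when a ring enters, whereas methyl in place of hydrogen on the sulfonamide nitrogen gave no change at the digits printed from compound 1 to compound 2 (within the scatter). Nothing at hand accounts for the size of these steps.

Still open, on these data alone, is whether the steps follow the ring itself or the ring oxygen. Piperidin-1-yl, with carbon in place of that oxygen, and piperazin-1-yl, with an amine nitrogen there, would separate the two readings.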